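The compounds below may be only part of what the source reports. "The series", "measured", "known", "first", "only" and "open" are said of these compounds alone.

Measured so far:
compound 1 `Cc1cc(C)c2cc(C#N)c(NCCNC(=O)c3cccnc3)nc2c1`: 2700 nM in an in vitro assay on FRT cells with Cystic fibrosis transmembrane conductance regulator variant F508del (Homo sapiens) as the target, read by fluorescence, with a stated time of 24 h, at 37 degrees C, in the presence of a further agent that is not named here; a higher number here means that more compound is needed for the effect, a lower number that less compound is needed
compound 2 `Cc1cc(C)c2cc(C#N)c(NCCNC(=O)c3ccncc3)nc2c1`: 7300 nM in this assay
compound 3 `Cc1cc(C)c2cc(C#N)c(NCCCNC(=O)c3cccnc3)nc2c1`: 3000 nM in this assay

Compound 1 and compound 2 share a core and differ only at the amide end: pyridin-4-yl in place of pyridin-3-yl on a carbonyl carbon. That change gives a 2.7-fold higher number from compound 1 to compound 2 (0.43 log units; beyond the scatter). Compound 3 carries a core that is not the same as that of compound 1; the difference between the two cores is not broken down here. In this assay compound 3 and compound 1 give numbers that lie within the scatter of each other, so nothing is made of their order.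

Compound 4 `Cc1cc(C)c2cc(C#N)c(NCCCNC(=O)c3ccncc3)nc2c1` is not yet measured. It stands to compound 3 as compound 2 stands to compound 1: pyridin-4-yl in place of pyridin-3-yl on a carbonyl carbon. The place is the same in both pairs, the carbonyl carbon bearing an amide-type nitrogen, so this is the same change. Among the measured compounds shown here, the single precedent, from compound 1 to compound 2, is modest but beyond the scatter. A step of like size is expected from compound 3 to compound 4, a 2.7-fold higher number from compound 3 to compound 4 (0.43 log units; beyond the scatter), resting on that precedent, because compound 3 gives 3000 nM. The estimate for compound 4 in this assay is 8000 nM, with a range from 3500 nM to 18000 nM.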

Compound 4, half-maximal effective concentration: 8200 nM
Compound 4: the middle estimate sits 1.0-fold (0.01 log units) below what was measured; the range from low to high includes it.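

On the core of compound 3, pyridin-4-yl in place of pyridin-3-yl on a carbonyl carbon gives a 2.7-fold higher number from compound 3 to compound 4 (0.44 log units; beyond the scatter) in this assay. Set beside the earlier step, the change carries from one core to the other with no difference in size: the same change on two cores in this assay, a 2.7-fold higher number (0.43 log units; beyond the scatter) from compound 1 to compound 2 and a 2.7-fold higher number (0.44 log units; beyond the scatter) from compound 3 to compound 4, 1.0-fold (0.00 log units) apart, within the scatter of two such steps. This shows that the step held on these two cores in this one assay; it does not show that it would hold on a more distant core, nor does it explain why the pyridin-3-yl amides give the lower numbers.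

On these data alone, the amide end is represented only by pyridin-3-yl and pyridin-4-yl, so it stays open whether pyridin-2-yl, phenyl or pyrimidinyl would fit the same order. Among the compounds shown here, also open are the effects of a longer chain in place of the one in compound 4 and of replacing the nitrile or the methyl groups, which stay the same in all four compounds.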